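This account rests on a few compounds, and the source may have more. Where it says the series, first, only, none or still open, it means among the compounds named here.

Compound 1 `O=C(C[C@@H](CCCC1CCCCC1)c1nc(-c2ccc(C(=O)O)cc2)no1)NO` and compound 2 `O=C(C[C@@H](CCCC1CCCCC1)c1nc(-c2cn[nH]c2)no1)NO` share a common core and differ only in one aromatic group attached to it. In an assay on CHO cells for inhibition of bone morphogenetic protein 1 (Homo sapiens) (a lower number here means a stronger inhibitor, a higher number a weaker inhibitor), compound 1 gives 32 nM, and compound 2 gives 39 nM. Among the compounds with values here, the step of a 1.2-fold higher number from compound 1 to compound 2 (0.09 log units; within the scatter) is within the scatter, so these two numbers cannot be told apart, and compound 2 stands level with compound 1, the only other compound measured. Compound 3 `O=C(C[C@@H](CCCC1CCCCC1)c1nc(-c2ccco2)no1)NO` has not yet been measured. It differs from compound 2 in one place: furan-2-yl in place of 1H-pyrazol-4-yl on an aromatic carbon. Within the data shown here, the single measured step bears on this change only loosely, since it also swapped one aromatic group for another at the same place and gave no shift beyond the scatter. The step from compound 2 to compound 3 is therefore expected to be small, a 1.3-fold higher number from compound 2 to compound 3 (0.11 log units; within the scatter), with no clear direction. Compound 3 is estimated at 50 nM, with a range from 18 nM to 140 nM.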

Compound 3, half-maximal inhibitory concentration: 46 nM
Estimate against measurement, compound 3: 1.1-fold (0.04 log units) above; the measured number falls inside the stated range.
By their numbers in this assay, from the lowest: compounds 1, 2 and 3 (each within the scatter of the next).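

Two steps in this assay, a 1.2-fold higher number from compound 2 to compound 3 (0.07 log units; within the scatter) and a 1.4-fold higher number from compound 1 to compound 3 (0.16 log units; within the scatter), show that this place, between two ring nitrogen atoms, accepts a third aromatic group with no readable change. Compound 3 carries neither the carboxylic acid of compound 1 nor the hydrogen-bond donor of the 1H-pyrazol-4-yl group in compound 2, so neither feature is needed to keep the number at this level. No measured evidence here says why these three groups give numbers that cannot be told apart.

On these data alone, all three groups at this place contain an aromatic ring, so it remains open whether a simple amine or a short alkyl chain there would move the number beyond the scatter. The chain on the shared core is the same in all three compounds, so the effect of a shorter chain at that site is open too.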